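Amide substituent change in a dihydrofuran carboxamide series

This account rests on a few compounds, and the source may have more. Where it says the series, first, only, none or still open, it means among the compounds named here.

Compound 1 `C=CC1=C(C(=O)NCCCCC)C(c2ccc(OC)cc2)OC1`: > 100000 nM
Compound 2 `C=CC1=C(C(=O)NCCCCC)C(c2ccc(F)cc2)OC1`: > 100000 nM
Compound 3 `C=CC1=C(C(=O)NCc2ccc(C)cc2)C(c2ccc(OC)c(OC)c2)OC1`: 69100 nM

In a functional assay on QGY7701 cells (Homo sapiens) for cytotoxicity, read by MTT assay, with a stated time of 24 h (a higher number here means a weaker inhibitor, a lower number a stronger inhibitor), compound 1 stands only at a limit of the assay. Compound 2 likewise stands at that limit, so the step that the two limits leave unreadable from compound 1 to compound 2 cannot be read. Two of the three values sit at the limit of > 100000 nM in this assay, at which 2 of the 3 values shown sit; compound 3 alone gives a measured number, 69100 nM.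

Compound 4 `C=CC1=C(C(=O)NCc2ccccc2)C(c2ccc(OC)cc2)OC1` differs from compound 1 by phenyl in place of butyl on a saturated chain carbon bound to an amide-type nitrogen. For the measured compounds named here, no measured step covers this change. Compound 3 carries a benzyl-type amide and a measured value, so compound 4 is expected to fall near the limit or a little inside it. Compound 4 is estimated at 90000 nM, within 35000 nM to 250000 nM. The expected step is an at least 1.1-fold lower number from compound 1 to compound 4 (0.04 log units; that floor lies within the scatter), uncertain in size.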

Compound 4, half-maximal inhibitory concentration: > 100000 nM
Compound 4: a limit, no number; the forecaster's own chance of this, stated with the estimate: 45%; at least 1.1-fold (0.04 log units) between middle value and limit.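

Compound 4 stands only at a limit, > 100000 nM, and compound 1 is also a limit, so no step between compound 1 and compound 4 can be read: the limit of > 100000 nM in this assay, at which 3 of the 4 values shown sit.

Going by these compounds, how any single change on the shared core moves the value stays open; only compound 3 gives a measured number.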